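Adding a Second Fluoro: Expected Dose for Compound 4

The compounds below may be only part of what the source reports. "The series", "measured", "known", "first", "only" and "open" are said of these compounds alone.

Compound 1 `CC(C)NC(=O)/C=C1\CCc2ccc(F)cc21`: 96 mg/kg
Compound 2 `CC(C)NC(=O)/C=C1\CCc2c(F)cc(F)cc21`: 50 mg/kg
Compound 3 `NC(=O)/C=C1\CCc2cc(F)ccc21`: 56 mg/kg

These three compounds were tested in a functional assay on the whole organism with Mus musculus as the target; on this read-out higher numbers stand for an effect only at larger amounts of compound and lower numbers for an effect already at smaller amounts. Compound 2 differs from compound 1 by fluoro in place of hydrogen on an aromatic carbon, and the step is a 1.9-fold lower number from compound 1 to compound 2 (0.28 log units; within the scatter). The difference between the cores of compound 1 and compound 3 is not broken down here. Compound 4 `NC(=O)/C=C1\CCc2c1ccc(F)c2F`, not yet measured, differs from compound 3 by fluoro in place of hydrogen on an aromatic carbon. In compound 4 the entering fluoro is ortho to a fluoro group, whereas in compound 2 it is meta to a fluoro group, so the two changes are of the same kind, not the same. A step of a 1.6-fold lower number from compound 3 to compound 4 (0.20 log units; within the scatter) is expected from compound 3 to compound 4, resting on the earlier step because a 1.9-fold lower number from compound 1 to compound 2 (0.28 log units; within the scatter) was seen for the same kind of change. The estimate for compound 4 in this assay is 35 mg/kg, with a range from 15 mg/kg to 85 mg/kg.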

Compound 4, dose for half-maximal effect: 45 mg/kg
Beside the measured number, compound 4's estimate is 1.3-fold (0.11 log units) below it; measured number inside the range.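

In this assay, fluoro entering ortho to a fluoro group gives a 1.2-fold lower number from compound 3 to compound 4 (0.09 log units; within the scatter). Set beside the earlier step, the two do not differ: the same change on two cores in this assay, a 1.9-fold lower number (0.28 log units; within the scatter) from compound 1 to compound 2 and a 1.2-fold lower number (0.09 log units; within the scatter) from compound 3 to compound 4, 1.5-fold (0.19 log units) apart, within the scatter of two such steps. The change therefore carries across these two cores without a difference that can be told apart, but with both steps within the scatter, this does not show that the added fluoro lowers the dose on either core, and with the entering fluoro placed differently on the two cores, any influence of core and of position cannot be separated.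

The compounds shown leave open whether chloro, methoxy or trifluoromethyl in the same place would give a clearer step. They also leave open how a carboxylic acid in place of the amide would read out.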